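Working notes on a guanidine amide series: alkoxy chain extension

The compounds below may be only part of what the source reports. "The series", "measured", "known", "first", "only" and "open" are said of these compounds alone.

Measured so far in a functional assay on the whole organism for inhibition, with Mus musculus as the target, at a dose of 20 mg/kg by the intraperitoneal route; on this read-out higher numbers stand for more inhibition at the one dose given (going by the name of the read-out) and lower numbers for less inhibition:
Compound 1, `Cc1ccc(C(=O)NC(=N)NCCCCc2ccccc2)cc1`, gives 75%.
Compound 2, `Cc1ccc(C(=O)NC(=N)NCCCCCc2ccccc2)cc1`, gives 7%.
Compound 3, `CCOc1ccc(C(=O)NC(=N)NCCCCc2ccccc2)cc1`, gives 60%.

Compound 3 stands second of the three numbers, beyond the scatter below compound 1 and well beyond the scatter above compound 2. Two steps have been measured. From compound 1 to compound 2, a number 68 percentage points lower from compound 1 to compound 2 (beyond the scatter), a benzyl in place of phenyl on a saturated chain carbon four bonds along from an amine nitrogen: a large loss on lengthening the chain at that end. From compound 1 to compound 3, a number 15 percentage points lower from compound 1 to compound 3 (beyond the scatter), ethoxy in place of methyl on an aromatic carbon: a modest loss.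

Compound 4, `CCCCOc1ccc(C(=O)NC(=N)NCCCCc2ccccc2)cc1`, has not been measured. It differs from compound 3 by ethyl in place of hydrogen on a saturated chain carbon, two bonds along the chain from an oxygen on an aromatic ring. Within the data shown here, only the step from compound 1 to compound 3 touches this part of the molecule, and it was a modest fall; the step from compound 1 to compound 2 shows that chain lengthening elsewhere in the core was costly. Both point the same way, so a further fall is expected, of uncertain size. The estimated step from compound 3 to compound 4 is a number 20 percentage points lower from compound 3 to compound 4 (beyond the scatter). Compound 4 is therefore expected to give about 40%, between 10% and 65%.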

Compound 4, a percentage reported as inhibition, in the whole organism at one dose (the size of the read-out at that dose, not a potency): 97%
Estimate against measurement, compound 4: 57 percentage points below, and the stated range ends below it.
By their numbers in this assay, from the lowest: compound 2; then compound 3; then compound 1; then compound 4.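

In this assay, the change from ethoxy to butoxy gives a number 37 percentage points higher from compound 3 to compound 4 (beyond the scatter), which reverses the direction of a number 15 percentage points lower from compound 1 to compound 3 (beyond the scatter), so the response at this position does not fall steadily as the group on the aromatic carbon grows. Butoxy also clears the methyl of the starting compound, with a number 22 percentage points higher from compound 1 to compound 4 (beyond the scatter), and compound 4 at 97% ranks highest of the four, so lengthening here does not follow the large loss of a number 68 percentage points lower from compound 1 to compound 2 (beyond the scatter) seen on lengthening the chain that carries the phenyl. Nothing measured accounts for this turn between ethoxy and butoxy.

As far as these compounds go, with only methyl, ethoxy and butoxy at this position, the shape of the trend remains open: propoxy would show where the turn lies, and a longer chain such as hexyloxy would show whether the rise continues or fails. From the compounds shown here alone, since this assay reports the size of the effect at one dose, it also remains open whether compound 4 differs from compound 1 in potency or only in the response at that dose.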